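Isopropoxy for methoxy on the pyridine oxygen of compound 1

The source may report more compounds than this note shows. Statements on the series, on what has been measured and on what is new or still open speak of the compounds shown alone.

Compound 1 `COc1ccc(NC(=O)C(=O)c2cn(C(C)C)c3ccccc23)cn1` gives the lowest number of the three measured compounds in a functional assay on FaDu cells (Homo sapiens) for cytotoxicity, read by MTT assay, with a stated time of 72 h (on this read-out higher numbers stand for lower toxicity in this test and lower numbers for higher toxicity in this test), at 85 nM. Compound 3 `COC(=O)CCn1cc(C(=O)C(=O)Nc2ccc(OC)nc2)c2ccccc21` sits nearest, at 168 nM, a step of a 2.0-fold higher number from compound 1 to compound 3 (0.30 log units; within the scatter). Compound 2 `COc1ccc(NC(=O)C(=O)c2cn(C(C)C)c3cccc(OC)c23)cn1` lies furthest, at 7780 nM, a step of a 92-fold higher number from compound 1 to compound 2 (1.96 log units; beyond the scatter). Compound 4 `CC(C)Oc1ccc(NC(=O)C(=O)c2cn(C(C)C)c3ccccc23)cn1` differs from compound 1 in one place: isopropyl in place of methyl on an oxygen on an aromatic ring. Neither measured step touches that oxygen. The step to compound 3 shows that a change on the aromatic nitrogen stays within the scatter, while the step to compound 2 shows a large loss from a change on the core. Since nothing measured bears on the oxygen directly, a modest rise is expected for compound 4, a 2.4-fold higher number from compound 1 to compound 4 (0.37 log units; beyond the scatter), giving an estimated 200 nM within 60 nM to 800 nM.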

Compound 4, concentration lethal to 50% of the cells: 408 nM
Estimate against measurement, compound 4: 2.0-fold (0.31 log units) below; measured number inside the range.
By their numbers in this assay, from the lowest: compounds 1 and 3 (each within the scatter of the next); then compound 4; then compound 2.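

Methoxy to isopropoxy is the first change shown on an oxygen on an aromatic ring, and in this assay it gives a 4.8-fold higher number from compound 1 to compound 4 (0.68 log units; beyond the scatter), so this position responds to the change. Unlike the step on the aromatic nitrogen to compound 3, which stays within the scatter, this step lies beyond it. Nothing available explains the rise.

A single pair sets no trend for this oxygen. The compounds shown leave open how ethyl, a longer chain or a chain ending in an amine would read there.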